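This account rests on a few compounds, and the source may have more. Where it says the series, first, only, none or still open, it means among the compounds named here.

Of the compounds shown here, three have so far been measured in a functional assay on the whole organism for inhibition, with Rattus norvegicus as the target; a higher number here means that more compound is needed for the effect, a lower number that less compound is needed.

Compound 1 `CCCc1cccc(CC(C)(Oc2ccc(C(C)C)cc2)C(=O)O)c1` gives 1 mg/kg in this assay.
Compound 2 `CCCCc1cccc(CC(C)(Oc2ccc(C(C)C)cc2)C(=O)O)c1` gives 1 mg/kg in this assay.
Compound 3 `CCc1ccc(CC(C)(Oc2ccc(C(C)C)cc2)C(=O)NS(=O)(=O)C(F)(F)F)cc1` gives > 10 mg/kg in this assay, and this is a limit of the assay rather than a number, the limit at the limit of > 10 mg/kg in this assay, at which 1 of the 3 values shown sits.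

Compound 1 and compound 2 differ in one place: methyl in place of hydrogen on a saturated chain carbon, three bonds along the chain from an aromatic carbon. The step is no change at the digits printed from compound 1 to compound 2 (within the scatter). Compound 3 differs from compound 1 in more than one place, and the difference between the two cores is not broken down here.

Compound 4 `CCCc1ccc(CC(C)(Oc2ccc(C(C)C)cc2)C(=O)NS(=O)(=O)C(F)(F)F)cc1` has not yet been measured. It differs from compound 3 by methyl in place of hydrogen on a saturated chain carbon, two bonds along the chain from an aromatic carbon. This is the same kind of change as that from compound 1 to compound 2, though not the same: there the added methyl sits three bonds along the chain from an aromatic carbon, here two bonds along. The expected step is a step that the limit leaves unreadable from compound 3 to compound 4, which rests on the unchanged value across no change at the digits printed from compound 1 to compound 2 (within the scatter) and on compound 3 sitting at its limit > 10 mg/kg. Compound 4 is therefore estimated to give 20 mg/kg, most likely again reported only as a limit.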

Compound 4, dose for half-maximal effect: > 10 mg/kg
Compound 4 was reported as a limit; the forecaster's own chance of this, stated with the estimate: 70%; the middle value is on the limit's open side.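

In this assay compound 3 and compound 4 are both reported only as limits of the assay, so no step can be read between them, because both values stand at the same limit: the limit of > 10 mg/kg in this assay, at which 2 of the 4 values shown sit. The compounds shown leave open whether going from ethyl to propyl on this core changes the dose needed at all.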